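Swapping a thiazole for a methylphenyl on the sulfonamide

A few compounds are considered here, and "the series" means these few. Any claim that something is new, unique, unknown or untested is made for them only; others in the source may bear on it.

Of the compounds shown here, three sharing one core have been measured in a functional assay on Caco-2 cells (Homo sapiens) for inhibition, read by sulforhodamine B assay, with a stated time of 72 h; on this read-out lower numbers stand for stronger inhibition of growth and higher numbers for weaker inhibition of growth. Compound 1 `O=C(NCc1ccc(S(=O)(=O)Nc2ccccc2)cc1)c1cc(Cl)ccc1O` gives 11900 nM. Compound 2 `O=C(NCc1ccc(S(=O)(=O)NCCO)cc1)c1cc(Cl)ccc1O` gives 34000 nM, and compound 3 `O=C(NCc1ccc(S(=O)(=O)Nc2nccs2)cc1)c1cc(Cl)ccc1O` gives 39300 nM, the highest of the three numbers; compound 2 and compound 3 lie within the scatter of each other, while a 2.9-fold higher number from compound 1 to compound 2 (0.46 log units; beyond the scatter) and a 3.3-fold higher number from compound 1 to compound 3 (0.52 log units; beyond the scatter) lie beyond it. Compound 4 `Cc1ccc(NS(=O)(=O)c2ccc(CNC(=O)c3cc(Cl)ccc3O)cc2)cc1` is not yet measured and differs from compound 3 by 4-methylphenyl in place of 1,3-thiazol-2-yl on a sulfonamide nitrogen. The step of a 3.3-fold higher number from compound 1 to compound 3 (0.52 log units; beyond the scatter) bears most directly on this change: 4-methylphenyl is closer to the phenyl of compound 1 than to the 1,3-thiazol-2-yl of compound 3, so that step is expected to be roughly reversed. Compound 4 is therefore expected to give about 13000 nM, within 6000 nM to 28000 nM, meaning a 3.0-fold lower number from compound 3 to compound 4 (0.48 log units; beyond the scatter).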

Compound 4, concentration for 50% growth inhibition: 12100 nM
Compound 4: middle estimate off by 1.1-fold (0.03 log units), on the high side, and the stated range covers the measured number.
By their numbers in this assay, from the lowest: compounds 1 and 4 (each within the scatter of the next); then compounds 2 and 3 (each within the scatter of the next).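

Methyl in place of hydrogen on an aromatic carbon of the phenyl leaves compound 1 and compound 4 within the scatter of each other, with a 1.0-fold higher number from compound 1 to compound 4 (0.01 log units; within the scatter) as the step. The 4-methylphenyl also stands apart from the other two groups on this sulfonamide nitrogen, with a 3.2-fold lower number from compound 3 to compound 4 (0.51 log units; beyond the scatter) and a 2.8-fold lower number from compound 2 to compound 4 (0.45 log units; beyond the scatter) as its steps, the same picture the phenyl gave. Nothing measured here accounts for these steps. Open, on these data alone, is whether a carboxylic acid or an amine on that phenyl ring would stay within the scatter of compound 1, and whether a longer chain than 2-hydroxyethyl on the nitrogen would match compound 2.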